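Replacing a fluorophenyl ether with a naphthyl ether

A few compounds are considered here, and "the series" means these few. Any claim that something is new, unique, unknown or untested is made for them only; others in the source may bear on it.

Measured compounds:
compound 1 `COc1cc(C#N)ccc1OCCCN1CCC(C(c2ccc(F)cc2)c2ccc(F)cc2)CC1` 2 nM
compound 2 `N#Cc1ccc(OCCCN2CCC(C(c3ccc(F)cc3)c3ccc(F)cc3)CC2)cc1` 5.01 nM
compound 3 `Fc1ccc(OCCCN2CCC(C(c3ccc(F)cc3)c3ccc(F)cc3)CC2)cc1` 1.26 nM

In a functional assay (aorta) with Oryctolagus cuniculus as the target (a higher number here means weaker binding, a lower number tighter binding), compound 3 gives the lowest of the three numbers; the steps that lead to it are a 1.6-fold lower number from compound 1 to compound 3 (0.20 log units; within the scatter) and a 4.0-fold lower number from compound 2 to compound 3 (0.60 log units; beyond the scatter). Compound 4 `Fc1ccc(C(c2ccc(F)cc2)C2CCN(CCCOc3ccc4ccccc4c3)CC2)cc1` differs from compound 3 by naphthalen-2-yl in place of 4-fluorophenyl on an oxygen on a saturated carbon. Among the compounds with values here, the steps that bear on this are the earlier swaps of the ring on that same oxygen, a 1.6-fold lower number from compound 1 to compound 3 (0.20 log units; within the scatter) and a 4.0-fold lower number from compound 2 to compound 3 (0.60 log units; beyond the scatter), both modest at most, so exchanging one uncharged aromatic ring for another here is expected to move this assay little, if at all, beyond the scatter. For compound 4 the expected step is a 1.3-fold higher number from compound 3 to compound 4 (0.10 log units; within the scatter), giving an estimate of 1.6 nM with a range from 0.5 nM to 5 nM.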

Compound 4, dissociation constant: 7.94 nM
Estimate against measurement, compound 4: 5.0-fold (0.70 log units) below; measured number outside the range, above it.
By their numbers in this assay, from the lowest: compounds 3 and 1 (each within the scatter of the next); then compounds 2 and 4 (each within the scatter of the next).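

In this assay, the ring on this oxygen matters more than the earlier swaps suggested. Naphthalen-2-yl gives a 6.3-fold higher number from compound 3 to compound 4 (0.80 log units; beyond the scatter) and a 4.0-fold higher number from compound 1 to compound 4 (0.60 log units; beyond the scatter), both beyond the scatter, while a 1.6-fold higher number from compound 2 to compound 4 (0.20 log units; within the scatter) stays within it, so uncharged aromatic rings are not freely interchangeable here. No available evidence explains this difference. The compounds shown leave open whether a 4-chlorophenyl or quinolinyl ring on this oxygen would keep the number as low as 4-fluorophenyl does, and whether a cyclohexyl ring would do the same.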